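Swapping amino for nitro on compound 2

The source may report more compounds than this note shows. Statements on the series, on what has been measured and on what is new or still open speak of the compounds shown alone.

In a functional assay on A2780 cells (Homo sapiens) for antiproliferative activity, read by MTT assay, with a stated time of 48 h (a higher number here means a weaker inhibitor, a lower number a stronger inhibitor), compound 1 `COc1ccc2c(/C=C/C(=O)c3cc(N)c(OC)c(OC)c3)c[nH]c2c1` gives 204 nM. Compound 2 `COc1ccc2c(/C=C/C(=O)c3cc(N)c(OC)c(OC)c3)cn(C)c2c1` gives 156 nM, and compound 3 `COc1cc(C(=O)/C=C/c2cn(C)c3ccccc23)cc(N)c1OC` gives 441 nM. Compound 2 thus sits at the low end of the three numbers, level with compound 1 within the scatter, while compound 3 stands clearly higher.

Compound 4 `COc1ccc2c(/C=C/C(=O)c3cc(OC)c(OC)c([N+](=O)[O-])c3)cn(C)c2c1` has not yet been measured. It differs from compound 2 by nitro in place of amino on an aromatic carbon.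

Two measured steps offer some guidance, though neither touches the amino group. Methyl in place of hydrogen on an aromatic nitrogen gives a 1.3-fold lower number from compound 1 to compound 2 (0.12 log units; within the scatter), which is no real change. Hydrogen in place of methoxy on an aromatic carbon gives a 2.8-fold higher number from compound 2 to compound 3 (0.45 log units; beyond the scatter), a modest step. These show that one small change to this series can shift the number noticeably, but all three measured compounds carry the amino group, so none tests its loss. The direction is therefore a judgement, and the range must stay wide.

In this assay, the expected change is a 3.2-fold higher number from compound 2 to compound 4 (0.51 log units; beyond the scatter), meaning a somewhat weaker inhibitor. For compound 4 the estimated value is 500 nM, with a range of 130 nM to 2500 nM.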

Compound 4, half-maximal inhibitory concentration: 952 nM
Beside the measured number, compound 4's estimate is 1.9-fold (0.28 log units) below it; low and high end bracket the measured number.
By their numbers in this assay, from the lowest: compounds 2 and 1 (each within the scatter of the next); then compound 3; then compound 4.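

In this assay, within the data shown here, nitro in place of amino gives a 6.1-fold higher number from compound 2 to compound 4 (0.79 log units; beyond the scatter), the first sign that this aromatic carbon, ortho to a methoxy group, responds to a change of the group it carries, since the earlier compounds all keep the amino group. This step and a 2.8-fold higher number from compound 2 to compound 3 (0.45 log units; beyond the scatter) both lead to a higher number, so neither the amino group nor the methoxy group on the compared positions can be changed in these two ways without a loss in this assay's read-out. The swap alters several things at once, as the amino group leaves with its hydrogen-bond donor and the larger nitro group enters with none, and no measurement at hand separates these differences or explains the rise.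

The compounds shown leave open whether the loss of the amino group or the arrival of the nitro group drives the step, and a methyl group, a hydroxyl group, an acetamide or plain hydrogen at this carbon would help to tell these apart. They also leave open whether the same swap would give a similar step on compound 1, which has hydrogen on the aromatic nitrogen, or on compound 3, which lacks the methoxy group on the other ring.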